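Chain length and cytotoxicity across four related compounds

The compounds below may be only part of what the source reports. "The series", "measured", "known", "first", "only" and "open" are said of these compounds alone.

Measured so far:
compound 1, `CC(=O)Nc1nc(N)nc2c1ncn2[C@H]1CO[C@@H](CO)O1`: > 100000 nM
compound 2, `CCCC(=O)Nc1nc(N)nc2c1ncn2[C@H]1CO[C@@H](CO)O1`: > 100000 nM
compound 3, `CCCCCCCCCCCCCC(=O)Nc1nc(N)nc2c1ncn2[C@H]1CO[C@@H](CO)O1`: 4600 nM

Compound 1 carries an acetamido group on the shared core. In a functional assay on CCRF-CEM cells (Homo sapiens) for cytotoxicity (on this read-out lower numbers stand for higher toxicity in this test and higher numbers for lower toxicity in this test), compound 1 gives > 100000 nM, which is a limit of the assay and not a number. Compound 2 differs from compound 1 by ethyl in place of hydrogen on a saturated chain carbon bound to a carbonyl carbon. In this assay compound 2 gives > 100000 nM, again a limit. The step between them is therefore a step that the two limits leave unreadable from compound 1 to compound 2, since both values sit at the limit of > 100000 nM in this assay, at which 2 of the 3 values shown sit.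

Compound 3 is the only one of the three to return a number: in this assay compound 3 gives 4600 nM. Its difference from compound 1 is not broken down here. From compound 2 it differs by a decyl group in place of hydrogen, and the step is an at least 21-fold lower number from compound 2 to compound 3 (1.33 log units; beyond the scatter).

Compound 4, `CCCCCCCCCCCCCCCC(=O)Nc1nc(N)nc2c1ncn2[C@H]1CO[C@@H](CO)O1`, has not yet been measured. It differs from compound 3 by ethyl in place of hydrogen on a saturated chain carbon, ten or more bonds along the chain from a carbonyl carbon. This is the same kind of change as that from compound 1 to compound 2, but the place differs: there the ethyl entered on a saturated chain carbon bound to a carbonyl carbon, here it enters on a saturated chain carbon many bonds along the chain from a carbonyl carbon. The earlier step gives no readable size, because the limit of > 100000 nM in this assay, at which 2 of the 3 values shown sit, hides it.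

For compound 4 the expectation rests on compound 3, whose value 4600 nM shows that the long chain brought a measurable number where the short chains did not. Adding ethyl to an already long chain is expected to move the number only modestly, so the step is estimated as a 1.5-fold lower number from compound 3 to compound 4 (0.19 log units; within the scatter). Compound 4 is accordingly estimated at 3000 nM, between 1000 nM and 10000 nM.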

Compound 4, half-maximal cytotoxic concentration: > 100000 nM
Compound 4: no number, only a limit; the forecaster's own chance of this, stated with the estimate: 5%; middle value at least 33-fold (1.52 log units) away from the limit.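

In this assay, ethyl in place of hydrogen on a saturated chain carbon, ten or more bonds along the chain from a carbonyl carbon, gives an at least 21-fold higher number from compound 3 to compound 4 (1.33 log units; beyond the scatter), which is beyond the scatter. This shows that adding ethyl to the long chain of compound 3 is not a negligible change in this series, and that among the four compounds only compound 3 returns a number, so longer is not simply lower: compound 4 goes against any such trend. It does not show that the change carries the same size from one compound to another, since the same kind of change on the shorter chain, from compound 1 to compound 2, and at a different place, cannot be read, leaving nothing to set beside the new step: the limit of > 100000 nM in this assay, at which 3 of the 4 values shown sit.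

The compounds shown leave open how the read-out runs over chains longer than that of compound 2 but shorter than that of compound 3, where the change from a number to a limit might be traced more closely. They also leave open whether a still longer chain, or a chain ending in an amine or a carboxylic acid, would return a number in this assay.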